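A Chlorine Added to the Benzyl Arm of Compound 3

The compounds below may be only part of what the source reports. "The series", "measured", "known", "first", "only" and "open" are said of these compounds alone.

Compound 1, `CC1=C(C(=O)Nc2ccc(Br)cc2)C(c2ccc(Cl)cc2Cl)N=C(SCc2ccccc2)N1`, gives 24.2% in a functional assay on the whole organism (artery, strain albino) with Rattus norvegicus as the target, with a stated time of 360 min, at a dose of 10 mg/kg by the oral route; a lower number here means less inhibition, a higher number more inhibition at the dose given (going by the name of the read-out).
Compound 2, `CC1=C(C(=O)Nc2ccc(Br)cc2)C(c2ccc(Cl)cc2Cl)N=C(SCc2ccccc2Cl)N1`, gives 38.1%.
Compound 3, `COc1ccc(C2N=C(SCc3ccccc3)NC(C)=C2C(=O)Nc2ccc(Br)cc2)cc1`, gives 18.6%.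

Compound 3 has the lowest of the three numbers, yet it is hard to separate from compound 1, since a number 5.6 percentage points lower from compound 1 to compound 3 (within the scatter). Only compound 2 stands clearly apart from it.

Compound 4, `COc1ccc(C2N=C(SCc3ccccc3Cl)NC(C)=C2C(=O)Nc2ccc(Br)cc2)cc1`, differs from compound 3 by chloro in place of hydrogen on an aromatic carbon. The same change has been measured once before, between compound 1 and compound 2, where it gave a number 13.9 percentage points higher from compound 1 to compound 2 (beyond the scatter). On that single precedent a modest rise in this assay is expected for compound 4, estimated as a number 13.4 percentage points higher from compound 3 to compound 4 (beyond the scatter). Compound 4 is therefore estimated at 32%, with a likely range from 18% to 46%.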

Compound 4, a percentage reported as inhibition, in the whole organism at one dose (the size of the read-out at that dose, not a potency): 20.6%
Estimate against measurement, compound 4: 11.4 percentage points above, and the stated range covers the measured number.
By their numbers in this assay, from the lowest: compounds 3, 4 and 1 (each within the scatter of the next); then compound 2.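

On the core carrying 4-methoxyphenyl, the change from benzyl to 2-chlorobenzyl gives a number 2 percentage points higher from compound 3 to compound 4 (within the scatter) in this assay, so the clear rise seen with 2,4-dichlorophenyl does not reappear here. With 2-chlorobenzyl in place, the swap of the other aryl group gives a number 17.5 percentage points lower from compound 2 to compound 4 (beyond the scatter), whereas the same swap with plain benzyl stayed within the scatter. Still, the two readings of the chloro change are not far enough apart to show that its effect depends on the core: the same change on two cores in this assay, a number 13.9 percentage points higher (beyond the scatter) from compound 1 to compound 2 and a number 2 percentage points higher (within the scatter) from compound 3 to compound 4, 11.9 percentage points apart, within the scatter of two such steps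

On these data alone, whether a nitrile on the benzyl ring, or a longer chain in place of benzyl, would move the number in this assay remains open.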